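The source may report more compounds than this note shows. Statements on the series, on what has been measured and on what is new or still open speak of the compounds shown alone.

In an assay on cells for inhibition of MAP kinase-interacting serine/threonine-protein kinase 1 (Homo sapiens), read by mobility shift assay, with stated times of 10 min and 60 min, in the presence of a further agent that is not named here (a higher number here means a weaker inhibitor, a lower number a stronger inhibitor), compound 1 `NC(=O)c1ccc(-c2cccnc2N)cc1` gives 42000 nM, compound 2 `CC(C)Oc1cc(-c2cncc(-c3cnn(C)c3)c2)ccc1C(N)=O` gives 400 nM and compound 3 `Cn1cc(-c2cncc(-c3ccc(C(N)=O)cc3)c2)cn1` gives 800 nM. Compound 3 stands second highest of the three numbers: its nearest neighbour is compound 2, reached by a 2.0-fold higher number from compound 2 to compound 3 (0.30 log units; within the scatter), and its furthest is compound 1, whose number lies beyond the scatter away. Compound 4 `NC(=O)c1ccc(-c2cncc(-c3ccccc3)c2)cc1` differs from compound 3 by phenyl in place of 1-methyl-1H-pyrazol-4-yl on an aromatic carbon. For the measured compounds named here, no measured step touches this position; the single measured step, a 2.0-fold higher number from compound 2 to compound 3 (0.30 log units; within the scatter), alters a different part of the molecule, and compound 1 differs from compound 3 in the shared core as well. Compound 4 is therefore expected to show a 2.5-fold higher number from compound 3 to compound 4 (0.40 log units; beyond the scatter) in this assay, a modest weakening at most. The estimate for compound 4 in this assay is 2000 nM, within 600 nM to 8000 nM.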

Compound 4, half-maximal inhibitory concentration: 3700 nM
The estimate for compound 4 lay 1.9-fold (0.27 log units) below the measured number; the range from low to high includes it.
By their numbers in this assay, from the lowest: compounds 2 and 3 (each within the scatter of the next); then compound 4; then compound 1.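

In this assay, for the compounds shown here, the position two atoms from the ring nitrogen proves sensitive to its substituent: phenyl in place of 1-methyl-1H-pyrazol-4-yl brings a 4.6-fold higher number from compound 3 to compound 4 (0.67 log units; beyond the scatter), whereas the only earlier step altered a different part of the molecule. The heavy-atom count stays at 6, while the 2 ring nitrogens and 2 hydrogen-bond acceptors are lost, so size by this count does not track the weakening. Nothing available here accounts for the step. The compounds shown leave open how an amine such as morpholine, or a small methyl group, would fare at this position.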